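The compounds below may be only part of what the source reports. "The series", "measured", "known", "first", "only" and "open" are said of these compounds alone.

In a functional assay on HepG2 cells (Homo sapiens) for inhibition, read by MTT assay (on this read-out higher numbers stand for weaker inhibition and lower numbers for stronger inhibition), compound 3 `COc1cc2ncnc(Nc3ccc(NC(=O)c4ccc(Cl)cc4)cc3)c2cc1OC` gives 28000 nM. Compound 1 `COc1cc2ncnc(Nc3ccc(NC(=O)c4ccccc4Cl)cc3)c2cc1OC` gives 26000 nM, and a 1.1-fold higher number from compound 1 to compound 3 (0.03 log units; within the scatter) keeps the two together. Compound 2 `COc1cc2ncnc(Nc3ccc(NC(=O)c4cccc(Cl)c4)cc3)c2cc1OC` gives 12000 nM, and a 2.2-fold lower number from compound 1 to compound 2 (0.34 log units; beyond the scatter) sets it apart, so compound 3 sits with compound 1 at the upper end of the numbers. Compound 4 `COc1cc2ncnc(Nc3ccc(NC(=O)c4cccc(C(F)(F)F)c4)cc3)c2cc1OC` carries 3-(trifluoromethyl)phenyl in place of 4-chlorophenyl on a carbonyl carbon. Within the data shown here, no measured compound holds trifluoromethyl, so the nearest guide is the 3-chlorophenyl of compound 2, where a 2.3-fold higher number from compound 2 to compound 3 (0.37 log units; beyond the scatter) was modest. A similar modest move toward a lower number is therefore expected, an estimated 2.0-fold lower number from compound 3 to compound 4 (0.30 log units; within the scatter). For compound 4 the expected value is 14000 nM, within an estimated range of 7000 nM to 28000 nM.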

Compound 4, half-maximal inhibitory concentration: 83000 nM
Compound 4: the middle estimate sits 5.9-fold (0.77 log units) below what was measured, outside the stated range (above it).
By their numbers in this assay, from the lowest: compound 2; then compounds 1 and 3 (each within the scatter of the next); then compound 4.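

In this assay, among these compounds, trifluoromethyl in place of chloro on an aromatic carbon gives the largest step so far, a 6.9-fold higher number from compound 2 to compound 4 (0.84 log units; beyond the scatter), so this swap is far from neutral. The number also rises with a 3.0-fold higher number from compound 3 to compound 4 (0.47 log units; beyond the scatter) and with a 3.2-fold higher number from compound 1 to compound 4 (0.50 log units; beyond the scatter), which puts 3-(trifluoromethyl)phenyl on the carbonyl carbon clearly on the weaker side of all three chlorophenyl groups. Nothing at hand explains this result.

On these data alone, it stays open whether a methoxy, an amine or a carboxylic acid in place of chloro would keep the number near that of compound 2 or raise it as trifluoromethyl did.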